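Series notes: methoxy in place of methyl toward compound 4

The source may report more compounds than this note shows. Statements on the series, on what has been measured and on what is new or still open speak of the compounds shown alone.

Measured so far in a functional assay on MDA-MB-231 cells (Homo sapiens) for cytotoxicity, read by MTT assay, with a stated time of 48 h; on this read-out higher numbers stand for weaker inhibition and lower numbers for stronger inhibition:
compound 1 `O=C(/C=C/c1ccc2c(c1)B(O)OC2)c1ccc(F)cc1`, 1600 nM
compound 2 `Cc1ccc(C(=O)/C=C/c2ccc3c(c2)B(O)OC3)cc1`, 6500 nM
compound 3 `Cc1cccc(C(=O)/C=C/c2ccc3c(c2)B(O)OC3)c1`, 4500 nM

Compound 3 stands second highest of the three numbers. Its nearest neighbour is compound 2, with a 1.4-fold lower number from compound 2 to compound 3 (0.16 log units; within the scatter); its furthest is compound 1, with a 2.8-fold higher number from compound 1 to compound 3 (0.45 log units; beyond the scatter). Compound 4 `COc1cccc(C(=O)/C=C/c2ccc3c(c2)B(O)OC3)c1` differs from compound 3 in methoxy in place of methyl on an aromatic carbon. Going by the values given here, no measured step exchanges methyl for methoxy, so the bearing of the known steps is loose: a 4.1-fold higher number from compound 1 to compound 2 (0.61 log units; beyond the scatter) and a 2.8-fold higher number from compound 1 to compound 3 (0.45 log units; beyond the scatter) are both modest, and a 1.4-fold lower number from compound 2 to compound 3 (0.16 log units; within the scatter) shows the two methyl variants within the scatter of each other. The expectation for compound 4 in this assay is therefore no step beyond the scatter, a 1.1-fold lower number from compound 3 to compound 4 (0.05 log units; within the scatter). Compound 4 is estimated at 4000 nM, with a range from 1500 nM to 11000 nM.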

Compound 4, half-maximal inhibitory concentration: 2100 nM
Beside the measured number, compound 4's estimate is 1.9-fold (0.28 log units) above it; measured number inside the range.
By their numbers in this assay, from the lowest: compounds 1 and 4 (each within the scatter of the next); then compounds 3 and 2 (each within the scatter of the next).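

Going by these compounds alone, at this aromatic carbon, methoxy in place of methyl gives a 2.1-fold lower number from compound 3 to compound 4 (0.33 log units; beyond the scatter) in this assay and so marks the first step beyond the scatter at this position. The earlier change to compound 3 from its methyl isomer gave only a 1.4-fold lower number from compound 2 to compound 3 (0.16 log units; within the scatter) and left the group itself unchanged. The change adds one oxygen and one hydrogen-bond acceptor, but nothing at hand accounts for the step. As far as these compounds go, whether the lower number follows the oxygen or the larger group stays open. Ethoxy, hydroxyl or an amine on this carbon would separate the two.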